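An Ethyl Group Enters Where Cyclopropyl Once Sat

The source may report more compounds than this note shows. Statements on the series, on what has been measured and on what is new or still open speak of the compounds shown alone.

Compound 1, `CCCc1nc(C)c2c(C3CC3)nnc(O)n12`, gives in a functional assay for inhibition, with Homo sapiens as the target (on this read-out lower numbers stand for stronger inhibition and higher numbers for weaker inhibition), only a limit, > 48000 nM, and not a number.
Compound 2, `CCc1nnc(O)n2c(C(C)(C)C)nc(C)c12`, gives in this assay 26000 nM.
Compound 3, `CCCc1nc(C)c2cnnc(O)n12`, gives in this assay 56800 nM.

Among the two numbers, compound 3 stands highest; its nearest neighbour is compound 2, whose value is lower by a margin beyond the scatter, while the third value is a limit. Compound 4, `CCCc1nc(C)c2c(CC)nnc(O)n12`, differs from compound 3 by ethyl in place of hydrogen on an aromatic carbon. Among the compounds with values here, the only measured step at this position is a step that the limit leaves unreadable from compound 1 to compound 3, which is unreadable because the limit of > 48000 nM in this assay, at which 1 of the 3 values shown sits, hides its size. No readable step bears on the change, so no direction can be expected beyond the scatter. Compound 4 is therefore estimated at 50000 nM, within 20000 nM to 120000 nM, a step of a 1.1-fold lower number from compound 3 to compound 4 (0.06 log units; within the scatter).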

Compound 4, half-maximal inhibitory concentration: 15600 nM
The estimate for compound 4 lay 3.2-fold (0.51 log units) above the measured number; measured number below the stated range.
By their numbers in this assay, from the lowest: compounds 4 and 2 (each within the scatter of the next); then compound 3.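

In this assay, within the data shown here, ethyl in place of hydrogen gives a 3.6-fold lower number from compound 3 to compound 4 (0.56 log units; beyond the scatter) at this position, the first readable step here. Ethyl in place of cyclopropyl gives an at least 3.0-fold lower number from compound 1 to compound 4 (0.48 log units; beyond the scatter) and no exact size, since compound 1 gives a limit and not a number: the limit of > 48000 nM in this assay, at which 1 of the 4 values shown sits. Propyl in place of tert-butyl on an aromatic carbon gives a 1.7-fold lower number from compound 2 to compound 4 (0.22 log units; within the scatter) and so shows no difference.

Going by these compounds, whether the lower number persists with a longer chain such as butyl, or with an amine on this carbon, stays open. A single step from hydrogen to ethyl sets no trend.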